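The source may report more compounds than this note shows. Statements on the series, on what has been measured and on what is new or still open speak of the compounds shown alone.

Measured so far:
compound 1, `C(=N/Nc1nc2ccccc2o1)\c1ccccn1`: 1440 nM
compound 2, `CC/C(=N\Nc1nc2ccccc2o1)c1ccccn1`: 409 nM

In a functional assay on HT-29 cells (Homo sapiens) for antiproliferative activity, read by sulforhodamine B assay (on this read-out higher numbers stand for weaker inhibition and lower numbers for stronger inhibition), compound 2 gives the lowest of the two numbers, and the gap to compound 1 lies beyond the usual scatter. Compound 3, `CCC/C(=N\Nc1nc2ccccc2o1)c1ccccn1`, differs from compound 2 by methyl in place of hydrogen on a saturated chain carbon, two bonds along the chain from a carbon with a double bond to nitrogen. Among the compounds with values here, no measured pair here shows a change of this kind, so the direction is open. The step from compound 2 to compound 3 is expected to be small, a 1.2-fold lower number from compound 2 to compound 3 (0.07 log units; within the scatter), and not beyond the scatter. Compound 3 is therefore estimated at 350 nM, within a range from 150 nM to 900 nM.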

Compound 3, half-maximal inhibitory concentration: 851 nM
Compound 3: the middle estimate sits 2.4-fold (0.39 log units) below what was measured; the range from low to high includes it.
By their numbers in this assay, from the lowest: compound 2; then compounds 3 and 1 (each within the scatter of the next).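

In this assay, extending the ethyl of compound 2 to the propyl of compound 3 gives a 2.1-fold higher number from compound 2 to compound 3 (0.32 log units; beyond the scatter) and so moves towards weaker inhibition. The step is modest but beyond the scatter, so this chain position responds to the addition of a single methyl. No supporting data account for this change. A single step cannot establish a trend along the chain. On these data alone, whether a longer butyl chain, a branched isopropyl group or a chain ending in an amine would weaken inhibition further or restore it remains open.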